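Trimming a methoxy on a pyrazolyl chalcone series

The compounds below may be only part of what the source reports. "The series", "measured", "known", "first", "only" and "open" are said of these compounds alone.

Of the compounds shown here, three with a shared core have been measured in a functional assay on BT-549 cells (Homo sapiens) for cytotoxicity, read by sulforhodamine B assay, with a stated time of 48 h, tested at 0.01 uM; on this read-out higher numbers stand for a weaker effect at the one concentration tested and lower numbers for a stronger effect. Compound 1 `COc1ccc(-c2cc(/C=C/C(=O)c3ccc(N)cc3)[nH]n2)cc1` gives 92%. Compound 2 `COc1cc(-c2cc(/C=C/C(=O)c3ccc(N)cc3)[nH]n2)cc(OC)c1OC` gives 85%, and compound 3 `COc1cc(-c2cc(/C=C/C(=O)c3ccc(Cl)c(Cl)c3)[nH]n2)cc(OC)c1OC` gives 89%. Going by the values given here, compound 2 thus sits within the scatter of both neighbours: the one single-place step, a number 4 percentage points higher from compound 2 to compound 3 (within the scatter), and the values of compound 1 and compound 2 lie close together. Compound 4 `COc1ccc(-c2cc(/C=C/C(=O)c3ccc(N)cc3)[nH]n2)cc1OC` differs from compound 2 by hydrogen in place of methoxy on an aromatic carbon. Among the compounds with values here, no measured step removes a methoxy from that ring, so nothing here bears directly on the change; the only step known is small. Compound 4 is therefore expected to show a number 3 percentage points higher from compound 2 to compound 4 (within the scatter), no step beyond the scatter, and its value in this assay is estimated at 88%, within 78% to 98%.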

Compound 4, a percentage reported as activity, at one concentration (the size of the read-out at that concentration, not a potency): 84%
Beside the measured number, compound 4's estimate is 4 percentage points above it; the measured number falls inside the stated range.
By their numbers in this assay, from the lowest: compounds 4, 2, 3 and 1 (each within the scatter of the next).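

In this assay, this position on the ring proves tolerant in both directions: hydrogen in place of methoxy gives (a number 1 percentage points lower from compound 2 to compound 4 (within the scatter)), and methoxy in place of hydrogen gives (a number 8 percentage points lower from compound 1 to compound 4 (within the scatter)). Neither step at this position goes beyond the scatter at the one concentration tested, so the read-out does not separate hydrogen from methoxy here. No evidence on why this is so is at hand.

From the compounds shown here alone, whether a hydroxy group, a fluorine atom or a longer chain such as ethoxy at this position would give a step beyond the scatter remains open. Also open, going by these compounds, is how this change would read at other concentrations.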